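Removing the nitro group from furan and thiophene thiosemicarbazones

The compounds below may be only part of what the source reports. "The series", "measured", "known", "first", "only" and "open" are said of these compounds alone.

Compound 1 `C=CCNC(=S)N/N=C/C=C/C=C/c1ccc([N+](=O)[O-])o1` carries a nitro group on its furan-type core. In an ADME assay on J774 cells (Mus musculus) for cytotoxicity, read by MTT assay, with a stated time of 48 h (a lower number here means a stronger inhibitor, a higher number a weaker inhibitor), compound 1 gives < 100 uM, which is a limit of the assay and not a number. Compound 2 `C=CCNC(=S)N/N=C/C=C/C=C/c1ccco1` differs by hydrogen in place of nitro on an aromatic carbon. In this assay compound 2 gives > 400 uM, again a limit rather than a number. The step is an at least 4.0-fold higher number from compound 1 to compound 2 (0.60 log units; beyond the scatter), and both ends rest on limits: the limit of < 100 uM in this assay, at which 2 of the 3 values shown sit, and (the limit of > 400 uM in this assay, at which 1 of the 3 values shown sits).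

Compound 3 `C=CCNC(=S)N/N=C/C=C/c1ccc([N+](=O)[O-])s1` belongs to a second core; how it differs from compound 1 is not broken down here. In this assay compound 3 gives < 100 uM, which is a limit of the assay and not a number.

Compound 4 `C=CCNC(=S)N/N=C/C=C/c1cccs1` is not yet measured. It differs from compound 3 by hydrogen in place of nitro on an aromatic carbon. This is the same kind of change as that from compound 1 to compound 2, though the place differs: here the ring is a five-membered aromatic ring with 1 sulfur, next to the ring sulfur, whereas there it was a ring with 1 oxygen, next to the ring oxygen. Resting on an at least 4.0-fold higher number from compound 1 to compound 2 (0.60 log units; beyond the scatter), the expected step is an at least 3.5-fold higher number from compound 3 to compound 4 (0.54 log units; beyond the scatter). Compound 4 is accordingly estimated at 350 uM, within 100 uM to 800 uM.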

Compound 4, concentration for 50% inhibition: > 400 uM
Compound 4: a limit, no number; the forecaster's own chance of this, stated with the estimate: 70%; middle value at least 1.1-fold (0.05 log units) away from the limit.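

In this assay, hydrogen in place of nitro gives an at least 4.0-fold higher number from compound 3 to compound 4 (0.60 log units; beyond the scatter), so the change moves the number in the same direction on the second core as on the first: the same change on two cores in this assay, an at least 4.0-fold higher number (0.60 log units; beyond the scatter) from compound 1 to compound 2 and an at least 4.0-fold higher number (0.60 log units; beyond the scatter) from compound 3 to compound 4; the limit leaves it open whether they differ. Within these two pairs the direction therefore carries over, with both nitro compounds at one limit of the assay and both hydrogen compounds at the other. This does not show how large the step truly is on either core or whether its size carries over, since each step is only a bound set by assay limits, and two cores say nothing about how the change would behave on a further core.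

The compounds shown leave open how an amine or a carboxylic acid in place of the nitro group would read in this assay. They also leave open whether the step holds when the allyl group on the thiosemicarbazone is replaced by a longer chain.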